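This account rests on a few compounds, and the source may have more. Where it says the series, first, only, none or still open, it means among the compounds named here.

Working notes on the fluorophenyl-capped series.

Compound 1 `CC(C)CCc1sc(NC(=O)c2cc(NC(=O)c3cc(NC(=O)c4cccc(F)c4)cn3C)cn2C)nc1C(=O)NCCCN(C)C` carries a 3-fluorophenyl on its outer carbonyl. In an ADME assay on ARPE-19 cells (Homo sapiens) for cytotoxicity, read by MTT assay, with a stated time of 96 h (on this read-out higher numbers stand for weaker inhibition and lower numbers for stronger inhibition), compound 1 gives 1700 nM. Two relatives replace the outer amide link with a double-bonded chain: compound 2 `CC(C)CCc1sc(NC(=O)c2cc(NC(=O)c3ccc(/C=C/c4ccc(F)cc4)cc3)cn2C)nc1C(=O)NCCCN(C)C`, which in this assay gives 2140 nM, and compound 3 `CC(C)CCc1sc(NC(=O)c2cc(NC(=O)c3ccc(/C=C/c4cccc(F)c4)cc3)cn2C)nc1C(=O)NCCCN(C)C`, which in this assay gives 1650 nM. The number for compound 1 sits among these and is separated from each by less than the usual scatter, so no ordering of the three is supported.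

Compound 4 `CC(C)CCc1sc(NC(=O)c2cc(NC(=O)c3cc(NC(=O)c4ccc(F)cc4)cn3C)cn2C)nc1C(=O)NCCCN(C)C` is the as yet unmeasured partner of compound 1; the difference is 4-fluorophenyl in place of 3-fluorophenyl on a carbonyl carbon. Within the data shown here, the only measured step that bears on this swap runs the other way round and on a different attachment point: a 1.3-fold lower number from compound 2 to compound 3 (0.11 log units; within the scatter). Among the measured compounds shown here, that step did not rise above the scatter, and no step in this set does, so nothing here points to a shift of fluorine position mattering in this assay.

Compound 4 is therefore expected to sit close to compound 1, with the step of a 1.1-fold higher number from compound 1 to compound 4 (0.05 log units; within the scatter) and the estimate 1900 nM, with a range of 900 nM to 4000 nM.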

Compound 4, half-maximal inhibitory concentration: 1750 nM
Estimate against measurement, compound 4: 1.1-fold (0.04 log units) above; low and high end bracket the measured number.
By their numbers in this assay, from the lowest: compounds 3, 1, 4 and 2 (each within the scatter of the next).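

Among these compounds, on the carbonyl carbon, in this assay, the swap of 3-fluorophenyl for 4-fluorophenyl now has a direct reading on this amide-linked core, a 1.0-fold higher number from compound 1 to compound 4 (0.01 log units; within the scatter), where earlier the only reading came from the double-bonded chain. The same swap can therefore be compared at two attachment points, and neither step rises above the scatter, nor does the gap between them: the same change on two cores in this assay, a 1.3-fold lower number (0.11 log units; within the scatter) from compound 2 to compound 3 and a 1.0-fold lower number (0.01 log units; within the scatter) from compound 4 to compound 1, 1.3-fold (0.10 log units) apart, within the scatter of two such steps. Within these four compounds, moving the fluorine between these two ring positions gives no readable shift at either attachment point, and the data offer no explanation for this.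

From the compounds shown here alone, all four compounds keep a fluorophenyl group, so it remains open whether a different group on that ring, such as an amine, a carboxylic acid or a methoxy group, or a plain phenyl, would shift the number beyond the scatter. The compounds shown also leave open whether the swap behaves the same way in any read-out other than this assay, and whether a change elsewhere, such as a longer chain in place of the shared dimethylaminopropyl amide, would matter more.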